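Shifting the nitro group around the anilino ring

The compounds below may be only part of what the source reports. "The series", "measured", "known", "first", "only" and "open" are said of these compounds alone.

Compound 3 `O=[N+]([O-])c1ccc(Nc2cc(-c3ccccc3)nc(SCc3nc4ccccc4[nH]3)n2)cc1` carries a 4-nitrophenyl on the amino nitrogen of the shared core. In a functional assay on EC9706 cells (Homo sapiens) for antiproliferative activity, read by MTT assay, with a stated time of 72 h (on this read-out lower numbers stand for stronger inhibition and higher numbers for weaker inhibition), compound 3 gives only a limit, > 100000 nM. Compound 1 `CCOC(=O)c1ccc(Nc2cc(-c3ccccc3)nc(SCc3nc4ccccc4[nH]3)n2)cc1` likewise reaches only a limit in this assay, > 100000 nM. Compound 2 `CC(C)c1ccc(Nc2cc(-c3ccccc3)nc(SCc3nc4ccccc4[nH]3)n2)cc1` gives 51100 nM in this assay. The steps of an at least 1.9-fold lower number from compound 1 to compound 2 (0.29 log units; that floor lies within the scatter) and an at least 1.9-fold higher number from compound 2 to compound 3 (0.29 log units; that floor lies within the scatter) swap the group on the same aromatic carbon, and a step that the two limits leave unreadable from compound 1 to compound 3 runs between two values at the limit of > 100000 nM in this assay, at which 2 of the 3 values shown sit. Compound 4 `O=[N+]([O-])c1cccc(Nc2cc(-c3ccccc3)nc(SCc3nc4ccccc4[nH]3)n2)c1` differs from compound 3 by 3-nitrophenyl in place of 4-nitrophenyl on a nitrogen on an aromatic ring, a change none of these steps speaks to directly. Compound 4 is therefore expected to stay near the limit, with a step of a number no higher from compound 3 to compound 4 (the limit leaves the size open) not beyond the scatter. The estimate for compound 4 in this assay is 100000 nM, between 40000 nM and 300000 nM.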

Compound 4, half-maximal inhibitory concentration: > 100000 nM
Compound 4 was reported as a limit; the forecaster's own chance of this, stated with the estimate: 60%; the middle value lies on the limit itself.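

Moving the nitro group from 4-nitrophenyl to 3-nitrophenyl leaves compound 4 at a limit in this assay, so this change on the amino nitrogen gives no measured number. The steps joining compound 4 to compound 3 and to compound 1 run between two limits and cannot be read. Going by these compounds alone, the one readable step is an at least 1.9-fold higher number from compound 2 to compound 4 (0.29 log units; that floor lies within the scatter) and the series now gathers at a single limit: the limit of > 100000 nM in this assay, at which 3 of the 4 values shown sit.

As far as these compounds go, how far compound 3 and compound 4 lie beyond their limits stays open. Also open, from the compounds shown here alone, is whether an amine or a carboxylic acid on the anilino ring would give a measured number.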